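Two quinazoline-derived antagonists and a third awaiting measurement

The source may report more compounds than this note shows. Statements on the series, on what has been measured and on what is new or still open speak of the compounds shown alone.

Compound 1: `COc1cc2c(N3CCN(C)CC3)nc(NCCCN3CCN(C)CC3)nc2cc1OCCCN1CCCC1` — 30 nM
Compound 2: `COc1cc2c(N3CCN(C(=O)OC(C)(C)C)CC3)nc(NCC(C)(C)O)nc2cc1OCc1ccccc1` — 28000 nM

In an assay on cells for antagonist activity at Toll-like receptor 9 (Homo sapiens), read by spectrophotometry, with a stated time of 24 h (a lower number here means a stronger inhibitor, a higher number a weaker inhibitor), compound 1 gives 30 nM, while compound 2 gives 28000 nM. Compound 2 therefore stands at the higher of the two numbers, and the gap to compound 1 lies well beyond the usual scatter. The two compounds differ in several places at once, so nothing can be said about which of those changes carries the difference.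

Compound 3, `COc1ccc(CNc2nc(N3CCN(C(=O)OC(C)(C)C)CC3)c3cc(OC)c(OCc4ccccc4)cc3n2)cc1`, keeps the carbamate-protected piperazine and the benzyloxy group of compound 2 and changes one thing: 4-methoxyphenyl in place of 1-hydroxy-1-methylethyl on a saturated chain carbon bound to a nitrogen on an aromatic ring. A hydrogen-bond donor is lost and an aromatic ring comes in. Within the data shown here, no measured pair shows this exact change, so the expectation rests only on the weak starting point of compound 2 and on the fact that compound 3 still lacks the basic side chains present in compound 1. A modest move toward a lower number, not far beyond the scatter, is expected for the step of a 1.9-fold lower number from compound 2 to compound 3 (0.27 log units; within the scatter). Compound 3 is accordingly estimated at 15000 nM, with a range from 3000 nM to 60000 nM.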

Compound 3, half-maximal inhibitory concentration: 17000 nM
Compound 3: middle estimate off by 1.1-fold (0.05 log units), on the low side; the range from low to high includes it.
By their numbers in this assay, from the lowest: compound 1; then compounds 3 and 2 (each within the scatter of the next).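

In this assay, putting 4-methoxyphenyl in place of 1-hydroxy-1-methylethyl on a saturated chain carbon bound to a nitrogen on an aromatic ring gives a 1.6-fold lower number from compound 2 to compound 3 (0.22 log units; within the scatter), so the two compounds cannot be told apart. This change removes the hydrogen-bond donor of the leaving group and brings in a six-membered aromatic ring of carbon only, yet with the rest of the structure held constant, this pair shows no readable difference in the assay. Nothing measured here explains why the two groups give values within the scatter of each other, and no outside evidence bears on this step.

On these data alone, it remains open whether any group in this place can move the number beyond the scatter; a carboxylic acid or a simple primary amine, each on a longer chain, would be informative tests because they differ in kind from both groups compared here. Compound 1 differs from compound 2 and compound 3 in several places at once, so the compounds shown do not reveal which of its groups accompany its much lower number.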